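Amide aryl change from compound 1 to compound 4

The source may report more compounds than this note shows. Statements on the series, on what has been measured and on what is new or still open speak of the compounds shown alone.

Measured so far: compound 1 `Cc1ccc(F)cc1NC(=O)CN1CCN(c2nnc(Cc3ccccc3)c3ccccc23)CC1` gives 19200 nM; compound 2 `Cc1ccc(F)cc1NC(=O)CN1CCN(c2nnc(Cc3ccncc3)c3ccccc23)CC1` gives 6.4 nM; compound 3 `O=C(CN1CCN(c2nnc(Cc3ccncc3)c3ccccc23)CC1)Nc1c(F)cccc1F` gives 1900 nM.

In a functional assay on MDA-MB-231 cells (Homo sapiens) for cytotoxicity, read by MTT assay, with a stated time of 72 h (on this read-out lower numbers stand for stronger inhibition and higher numbers for weaker inhibition), compound 1 stands at the highest of the three numbers, the weakest inhibition of the set. Both measured steps are large: a 3000-fold lower number from compound 1 to compound 2 (3.48 log units; beyond the scatter) and a 300-fold higher number from compound 2 to compound 3 (2.47 log units; beyond the scatter). Compound 4 `Cc1ccc(NC(=O)CN2CCN(c3nnc(Cc4ccccc4)c4ccccc34)CC2)c(C)c1` differs from compound 1 by 2,4-dimethylphenyl in place of 5-fluoro-2-methylphenyl on an amide-type nitrogen. Among the measured compounds shown here, the only step that bears on the amide-type nitrogen is a 300-fold higher number from compound 2 to compound 3 (2.47 log units; beyond the scatter), and it runs on a compound carrying pyridin-4-yl rather than phenyl and to a different group, so it shows that this position can move the number a long way but not in which direction here. Compound 4 is therefore expected close to compound 1, with broad uncertainty: a 1.3-fold higher number from compound 1 to compound 4 (0.11 log units; within the scatter). The estimate for compound 4 is 25000 nM, range 5000 nM to 100000 nM.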

Compound 4, half-maximal inhibitory concentration: 181000 nM
For compound 4 the middle estimate is 7.2-fold (0.86 log units) below the measured one; the measured number lies above the stated range.
By their numbers in this assay, from the lowest: compound 2; then compound 3; then compound 1; then compound 4.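

In this assay, the amide-type nitrogen position also moves the number when the chain carries phenyl rather than pyridin-4-yl: 2,4-dimethylphenyl in place of 5-fluoro-2-methylphenyl gives a 9.4-fold higher number from compound 1 to compound 4 (0.97 log units; beyond the scatter). The two groups have the same heavy-atom count and each holds one six-membered aromatic ring of carbon only, so a step of this size arises with those counts unchanged. No measurement at hand accounts for the step.

Still open, as far as these compounds go, is whether 2,4-dimethylphenyl moves the number in the same direction on compound 2, which carries pyridin-4-yl. Also open, from the compounds shown here alone, is how a methoxy group or an amine on the amide aryl ring reads.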